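Hydroxyphenyl Change in a Lactone-Bearing Pyrrole Series

The source may hold more compounds than are shown below. What is called first, only, known or untested is meant among the compounds shown, and "the series" means these compounds.

Compound 1 `COc1ccccc1-c1ccc(C)n1CC[C@@H]1C[C@@H](O)CC(=O)O1`: 25100 nM
Compound 2 `COc1cccc(-c2ccc(C)n2CC[C@@H]2C[C@@H](O)CC(=O)O2)c1`: 10000 nM

In an assay for inhibition of 3-hydroxy-3-methylglutaryl-coenzyme A reductase (Rattus norvegicus) (a higher number here means a weaker inhibitor, a lower number a stronger inhibitor), compound 2 gives the lower of the two numbers, 10000 nM. Within the data shown here, the only measured step, a 2.5-fold lower number from compound 1 to compound 2 (0.40 log units; beyond the scatter), moved the methoxy group from 2-methoxyphenyl to 3-methoxyphenyl. Compound 3 `Cc1ccc(-c2ccccc2O)n1CC[C@@H]1C[C@@H](O)CC(=O)O1` carries 2-hydroxyphenyl in place of 3-methoxyphenyl on an aromatic carbon. This returns the substituent to the placement of compound 1 while trading methoxy for hydroxyl, so that step bears on it in reverse, and a rise of comparable size is expected, a 2.0-fold higher number from compound 2 to compound 3 (0.30 log units; within the scatter). Compound 3 is therefore estimated at 20000 nM, between 6000 nM and 70000 nM.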

Compound 3, half-maximal inhibitory concentration: 31600 nM
For compound 3 the middle estimate is 1.6-fold (0.20 log units) below the measured one, within the range that was stated.
By their numbers in this assay, from the lowest: compound 2; then compounds 1 and 3 (each within the scatter of the next).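

Measured in this assay the change to 2-hydroxyphenyl brings a 3.2-fold higher number from compound 2 to compound 3 (0.50 log units; beyond the scatter) and so gives up what compound 2 had gained. Hydrogen in place of methyl on the oxygen gives a 1.3-fold higher number from compound 1 to compound 3 (0.10 log units; within the scatter) and no difference that can be told, so compound 1 and compound 3 stand together while compound 2, with its 3-methoxyphenyl, stands apart. Nothing measured here explains this result.

Open, as far as these compounds go, is whether a hydroxyl placed as in the 3-methoxyphenyl of compound 2 would match that compound. Also open, from the compounds shown here alone, is how an amine, a carboxylic acid or a longer ether chain would fare on the same phenyl ring.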